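The source may hold more compounds than are shown below. What is called first, only, known or untested is meant among the compounds shown, and "the series" means these compounds.

Measured in a functional assay on A549 cells (Homo sapiens) for cytotoxicity; a higher number here means a weaker inhibitor, a lower number a stronger inhibitor:
- Compound 1 `COCC1=C2/C(=C\[C@@]3(C)CC[C@](O)(O3)[C@@](C)(O)C[C@@H]2O)OC1=O`: > 5 ug/mL
- Compound 2 `CC(=O)OCC1=C2/C(=C\[C@@]3(C)CC[C@](O)(O3)[C@@](C)(O)C[C@@H]2O)OC1=O`: > 5 ug/mL

Compound 1 has no exact reading, since > 5 ug/mL is a limit of the assay. Compound 2 also has only a limit, > 5 ug/mL. The record so far is therefore (the limit of > 5 ug/mL in this assay, at which 2 of the 2 values shown sit).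

Compound 3 `COCC1=C2/C(=C\[C@@]3(C)CC[C@](O)(O3)[C@@](C)(O)C[C@@H]2OC(C)=O)OC1=O` has not yet been measured. It differs from compound 1 by acetyl in place of hydrogen on an oxygen on a saturated carbon, which is the change from hydroxy to acetoxy.

For the measured compounds named here, the one measured step that bears on this is a step that the two limits leave unreadable from compound 1 to compound 2. There, acetyl replaces methyl rather than hydrogen, and the step has no readable size to carry over. No step beyond the scatter is therefore expected in this assay, and no direction can be assigned.

The expected step is a step that the limit leaves unreadable from compound 1 to compound 3. For compound 3 the estimated value is 7 ug/mL, with an expected range of 2.5 ug/mL to 20 ug/mL.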

Compound 3, half-maximal inhibitory concentration: > 5 ug/mL
Compound 3: only a limit was reported (the forecaster's own chance of this, stated with the estimate: 70%); the middle value does not contradict the limit.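

Compound 3 gives > 5 ug/mL, which is a limit, so the comparison with compound 1 yields no readable step: the limit of > 5 ug/mL in this assay, at which 3 of the 3 values shown sit. The compounds shown leave open how strongly each one acts on these cells, and whether acetoxy in place of hydroxy changes that at all.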